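The compounds below may be only part of what the source reports. "The series", "measured", "known", "first", "only" and "open" are said of these compounds alone.

In a functional assay on MDA-MB-231 cells (Homo sapiens) for antiproliferative activity, read by XTT assay, with a stated time of 48 h (on this read-out lower numbers stand for stronger inhibition and higher numbers for weaker inhibition), the measured compounds are:

- compound 1 `CCCCN(Cc1cn([C@@H]2O[C@H](COC(C)=O)[C@@H](OC(C)=O)[C@H]2OC(C)=O)nn1)S(C)(=O)=O`: 225000 nM
- compound 2 `CC(=O)OC[C@H]1O[C@@H](n2cc(CN(c3ccc(C#N)cc3)S(C)(=O)=O)nn2)[C@H](OC(C)=O)[C@@H](OC(C)=O)[C@@H]1OC(C)=O`: 215000 nM
- compound 3 `CC(=O)OC[C@H]1O[C@@H](n2cc(CN(c3ccc(C#N)cc3)S(C)(=O)=O)nn2)[C@H](OC(C)=O)[C@@H](OC(C)=O)[C@H]1OC(C)=O`: 100000 nM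

Compound 3 has the lowest number of the three, so it is the strongest inhibitor so far, though all three values are high. Next comes compound 4 `CC(=O)OC[C@H]1O[C@@H](n2cc(CN(c3ccc(C#N)cc3)S(C)(=O)=O)nn2)[C@@H](OC(C)=O)[C@@H](OC(C)=O)[C@@H]1OC(C)=O`, and (the two compounds have the same atoms and bonds and differ only in configuration as drawn: 2 of 5 stereo elements differ; a stereocentre at a saturated ring carbon is drawn R in compound 3 and S in compound 4; a stereocentre at a saturated ring carbon is drawn S in compound 3 and R in compound 4). In other words, no group is added or lost, and only the spatial arrangement changes.

Going by the values given here, one measured step bears on this: a 2.2-fold lower number from compound 2 to compound 3 (0.33 log units; beyond the scatter). This step is modest but beyond the usual scatter, and it arises because of the fact that compounds 2 and 3 differ only in the configuration as drawn. A change of configuration can therefore shift the number in this assay, though only slightly in this one case. Two stereocentres change here rather than one, so the direction is uncertain. Compound 3 already holds the lowest value, so a modest rise towards the level of compound 2 at 215000 nM is the more likely outcome. The expected change is a 1.6-fold higher number from compound 3 to compound 4 (0.20 log units; within the scatter). For compound 4, the estimated value is 160000 nM, with an expected range of 80000 nM to 300000 nM.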

Compound 4, half-maximal inhibitory concentration: 230000 nM
For compound 4 the middle estimate is 1.4-fold (0.16 log units) below the measured one; the range from low to high includes it.
By their numbers in this assay, from the lowest: compound 3; then compounds 2, 1 and 4 (each within the scatter of the next).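

The new compound shows that compound 3 stands apart from a second compound with the same atoms and bonds in this assay, with a 2.3-fold higher number from compound 3 to compound 4 (0.36 log units; beyond the scatter), and this gap comes down to arrangement in space alone: the fact that compounds 3 and 4 differ only in the configuration as drawn. Inverting one saturated ring carbon does not always move the number, as the other new step shows a 1.1-fold higher number from compound 2 to compound 4 (0.03 log units; within the scatter). Of these three stereoisomers, only compound 3 separates from the other two, and at 100000 nM compound 3 remains a weak inhibitor.

The compounds shown do not tell whether any other arrangement of the ring carbons would give a much lower number. Also open, from the compounds shown here alone, is how a free hydroxyl in place of the acetate groups, or a carboxylic acid in place of the nitrile, would change the result.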